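This account rests on a few compounds, and the source may have more. Where it says the series, first, only, none or still open, it means among the compounds named here.

Measured in a functional assay on HL-60 cells (Homo sapiens) for inhibition, read by MTT assay, with a stated time of 48 h, tested at 10 uM; a higher number here means more inhibition of growth at the concentration tested, a lower number less inhibition of growth:
- compound 1 `Cc1cc(=O)c2c(O)c(CN3CCN(C(=O)OC(C)(C)C)CC3)c(O)c([C@H]3CCN(C)C[C@H]3O)c2o1`: 13%
- compound 2 `Cc1cc(=O)c2c(O)c(CN3CCCC3CO)c(O)c([C@H]3CCN(C)C[C@H]3O)c2o1`: 33%
- compound 3 `Cc1cc(=O)c2c(O)c(CN(C)CC(=O)O)c(O)c([C@H]3CCN(C)C[C@H]3O)c2o1`: 23%

Compound 3, at 23%, lies within the scatter of both compound 1 and compound 2. Compound 4 `CCOC(=O)N1CCN(Cc2c(O)c([C@H]3CCN(C)C[C@H]3O)c3oc(C)cc(=O)c3c2O)CC1` differs from compound 3 at one place: 4-(ethoxycarbonyl)piperazin-1-yl in place of (carboxymethyl)(methyl)amino on a saturated chain carbon bound to an aromatic carbon. Among the compounds with values here, the only measured step at this place is a number 10 percentage points lower from compound 2 to compound 3 (within the scatter). Among the measured compounds, compound 1 looks most like compound 4 at this place, and compound 1 gives 13%. A small change, not beyond the scatter, is therefore expected, with an estimated a number 5 percentage points lower from compound 3 to compound 4 (within the scatter). Compound 4 is expected to give 18%, with an estimated range from 6% to 32%.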

Compound 4, percent growth inhibition at one concentration: 16%
The estimate for compound 4 lay 2 percentage points above the measured number; the range from low to high includes it.
By their numbers in this assay, from the lowest: compounds 1, 4, 3 and 2 (each within the scatter of the next, the first and the last beyond it).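

In this assay, within the data shown here, 4-(ethoxycarbonyl)piperazin-1-yl gives the first step at this place that lies beyond the scatter (a number 17 percentage points lower from compound 2 to compound 4 (beyond the scatter)), while the step from the acid-bearing group stays within it (a number 7 percentage points lower from compound 3 to compound 4 (within the scatter)). Ethyl in place of tert-butyl on an oxygen next to a carbonyl group also leaves the reading within the scatter (a number 3 percentage points higher from compound 1 to compound 4 (within the scatter)). Nothing measured here explains these numbers. The compounds shown leave open how a piperazine with a free ring amine, or with a longer chain in place of ethyl, would read in this assay.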